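Vinyl for methoxy in the aryl thiophene acrylamides

The compounds below may be only part of what the source reports. "The series", "measured", "known", "first", "only" and "open" are said of these compounds alone.

Compound 1 `C/C(=C\c1cc(-c2ccc(S(C)(=O)=O)cc2)cs1)C(N)=O` and compound 2 `COc1ccc(-c2csc(/C=C(\C)C(N)=O)c2)cc1` share a core and differ in one group on the six-membered ring. In a functional assay on HeLa cells (Homo sapiens) for cytotoxicity, read by CCK-8 assay, with a stated time of 24 h (a higher number here means a weaker inhibitor, a lower number a stronger inhibitor), compound 1 gives > 50000 nM, which is a limit of the assay and not a number. In this assay compound 2 gives > 50000 nM, likewise a limit and not a number. Among the measured compounds shown here, the series so far shows only (the limit of > 50000 nM in this assay, at which 2 of the 2 values shown sit), and the step that the two limits leave unreadable from compound 1 to compound 2 cannot be read in size or direction. Compound 2 thus stands only at a limit, with no measured number to set against compound 1.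

Compound 3 `C=Cc1ccc(-c2csc(/C=C(\C)C(N)=O)c2)cc1` is the next member: vinyl in place of methoxy on an aromatic carbon. For the measured compounds named here, no measured step bears directly on this change; the only measured step, methoxy for methylsulfonyl, is itself unreadable, so no size can be taken from it. Since compound 2 sits at a limit, the expectation for this assay is no step beyond the scatter, with a strong chance that compound 3 again reports only a limit. The estimate for compound 3 is 60000 nM, between 30000 nM and 150000 nM. The expected step is a step that the limit leaves unreadable from compound 2 to compound 3.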

Compound 3, half-maximal inhibitory concentration: > 50000 nM
Compound 3: only a limit was reported; the forecaster's own chance of this, stated with the estimate: 80%; the middle value lies beyond the limit too.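

No step can be read among compound 1, compound 2 and compound 3 in this assay because each reports a limit of the assay and not a number: the limit of > 50000 nM in this assay, at which 3 of the 3 values shown sit.

In this assay the compounds shown leave open whether methylsulfonyl, methoxy and vinyl differ at all in their effect, and what any of the three steps would measure.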